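The source may hold more compounds than are shown below. What is called first, only, known or untested is meant among the compounds shown, and "the series" means these compounds.

Working notes on the series.

Compound 1 `O=C(c1ccccc1)c1cccc(NC(=O)C2CCCN(C(=O)c3cc(C(F)(F)F)cc(C(F)(F)F)c3)C2)c1` and compound 2 `C=CCOc1cccc(NC(=O)C2CCCN(C(=O)c3cc(C(F)(F)F)cc(C(F)(F)F)c3)C2)c1` share one core and differ only at one aromatic carbon. In an ADME assay on PC-3 cells (Homo sapiens) for cytotoxicity, read by WST assay, tested at 100 uM (on this read-out lower numbers stand for less inhibition and higher numbers for more inhibition at the one concentration tested (going by the name of the read-out)), compound 1 gives 0%, and in this assay compound 2 gives 0%. Within the data shown here, the one measured step, no change at the digits printed from compound 1 to compound 2 (within the scatter), therefore shows no movement on this read-out; compound 2 stands level with compound 1 at the digits reported, within the scatter.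

Compound 3 `Cn1cnnc1-c1cccc(NC(=O)C2CCCN(C(=O)c3cc(C(F)(F)F)cc(C(F)(F)F)c3)C2)c1` carries the change (4-methyl-4H-1,2,4-triazol-3-yl in place of allyloxy on an aromatic carbon). Among the measured compounds shown here, only one measured step bears on it, the exchange of benzoyl for allyloxy at the same aromatic carbon, and that step was flat. Two groups of quite different make-up at this position left the read-out unchanged, so the new group is not expected to move it either; the expected step of no change at the digits printed from compound 2 to compound 3 (within the scatter) is none beyond the scatter.

Compound 3 is accordingly estimated at 0% in this assay, with a range from -5% to 12%, the upper end allowing for ordinary scatter of a single-concentration measurement.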

Compound 3, a percentage reported as inhibition, at one concentration (the size of the read-out at that concentration, not a potency): 0%
Compound 3: the middle estimate sits on the measured number at the digits printed, and the stated range covers the measured number.
By their numbers in this assay, from the lowest: compounds 1, 2 and 3 (each within the scatter of the next).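

In this assay the 4-methyl-4H-1,2,4-triazol-3-yl group brings a five-membered aromatic ring with 3 hetero atoms to this aromatic carbon, and the read-out gives no change at the digits printed from compound 2 to compound 3 (within the scatter) and no change at the digits printed from compound 1 to compound 3 (within the scatter) in the notes. The earlier pair covered only benzoyl and allyloxy, whereas the flat result now extends to a third group, so on the shared core compound 1, compound 2 and compound 3 are not separated by this read-out at the one concentration tested. This holds for these three groups only, and nothing available ties the flat result to any feature of them.

From the compounds shown here alone, whether an amine, a carboxylic acid or a longer alkyl chain on this aromatic carbon would also stay level with compound 1 remains open. The compounds shown also differ at this one place only, which leaves open what replacing a trifluoromethyl group or the amide linker of the shared core with, for example, a chlorine or a sulfonamide would do to the read-out.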